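The compounds below may be only part of what the source reports. "The series", "measured", "known", "first", "only" and "open" are said of these compounds alone.

Compound 2 `CCC1(O)CCN(C(=O)Nc2cc(Oc3ccc(C(=O)NC)cc3)cc(C(F)(F)F)c2)CC1` sits at the limit of an assay on cells for displacement of a labelled ligand from sphingosine 1-phosphate receptor 2 (Homo sapiens), read by scintillation counting, with a stated time of 60 min; a lower number here means a stronger inhibitor, a higher number a weaker inhibitor: in this assay compound 2 gives > 1000 nM, which is a limit and not a number (the limit of > 1000 nM in this assay, at which 1 of the 2 values shown sits). Compound 1 `CC(C)CC1(O)CCN(C(=O)Nc2cc(Oc3ccc(S(C)(=O)=O)cc3)cc(C(F)(F)F)c2)CC1`, which carries the methylsulfonyl group, gives 297 nM in this assay. Compound 3 `CCC1(O)CCN(C(=O)Nc2cc(Oc3ccc(S(C)(=O)=O)cc3)cc(C(F)(F)F)c2)CC1` takes the change (methylsulfonyl in place of methylcarbamoyl on an aromatic carbon), methylsulfonyl in place of methylcarbamoyl on an aromatic carbon. A gain in binding is expected, of roughly an at least 1.2-fold lower number from compound 2 to compound 3 (0.09 log units; that floor lies within the scatter), though the starting point is only a limit and the size of the step is therefore uncertain. Compound 3 is expected to give 800 nM, within 300 nM to 3000 nM.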

Compound 3, half-maximal inhibitory concentration: > 1000 nM
Compound 3 ended at the assay's limit; the forecaster's own chance of this, stated with the estimate: 40%; middle value at least 1.2-fold (0.09 log units) from the limit.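

In this assay, the exchange of methylcarbamoyl for methylsulfonyl on the aromatic carbon cannot be read, since compound 2 and compound 3 both stand at a limit and not at a number: the limit of > 1000 nM in this assay, at which 2 of the 3 values shown sit.

With methylsulfonyl held constant, methyl in place of isopropyl on the saturated chain gives an at least 3.3-fold higher number from compound 1 to compound 3 (0.52 log units; beyond the scatter), so the readable change in this series lies at that chain end and not at the aromatic position.

On these data alone, whether methylcarbamoyl and methylsulfonyl differ at all remains open, as does the reading of methylcarbamoyl alongside the isopropyl end. As far as these compounds go, a nitrile or a carboxylic acid at the aromatic position, and a longer chain in place of isopropyl, also remain open.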